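From Phenyl to 6-Methylpyridin-3-yl on the Amide Nitrogen

A few compounds are considered here, and "the series" means these few. Any claim that something is new, unique, unknown or untested is made for them only; others in the source may bear on it.

Compound 1, `CN1C[C@H](C(=O)Nc2ccccc2)[C@@H](c2ccc(/C=C/C(=O)Nc3ccccc3N)cc2)C1`, gives 67 mL/min/kg in an in vitro ADME assay on microsomes from liver (Mus musculus) for pharmacokinetics, read by LC-MS, with a stated time of 10 min, tested at 1 uM (a lower number here means slower removal, a higher number faster removal of the compound), the second highest of the three numbers. Compound 2, `CN1C[C@H](C(=O)Nc2ccc(C(F)(F)F)cc2)[C@@H](c2ccc(/C=C/C(=O)Nc3ccccc3N)cc2)C1`, gives 23 mL/min/kg, and compound 3, `Cc1cccc(NC(=O)[C@H]2CN(C)C[C@@H]2c2ccc(/C=C/C(=O)Nc3ccccc3N)cc2)c1`, gives 74 mL/min/kg. Among the steps, a 2.9-fold lower number from compound 1 to compound 2 (0.46 log units; beyond the scatter) counts as modest, while a 1.1-fold higher number from compound 1 to compound 3 (0.04 log units; within the scatter) stays within the scatter; the step of a 3.2-fold higher number from compound 2 to compound 3 (0.51 log units; beyond the scatter) does not start from compound 1. Compound 4, `Cc1ccc(NC(=O)[C@H]2CN(C)C[C@@H]2c2ccc(/C=C/C(=O)Nc3ccccc3N)cc2)cn1`, differs from compound 1 by 6-methylpyridin-3-yl in place of phenyl on an amide-type nitrogen. Among the compounds with values here, no measured step exchanges the whole ring in this way, and the two steps out of compound 1 show one modest fall and one unchanged number, so a step of at most modest size, in an uncertain direction, is expected. For compound 4 the estimate is 50 mL/min/kg, with a range from 25 mL/min/kg to 100 mL/min/kg, meaning an expected step of a 1.3-fold lower number from compound 1 to compound 4 (0.13 log units; within the scatter).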

Compound 4, clearance: 57 mL/min/kg
Compound 4: middle estimate off by 1.1-fold (0.06 log units), on the low side, and the stated range covers the measured number.
By their numbers in this assay, from the lowest: compound 2; then compounds 4, 1 and 3 (each within the scatter of the next).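

Exchanging the whole phenyl ring for 6-methylpyridin-3-yl, which adds a ring nitrogen and a methyl, stays within the scatter in this assay (a 1.2-fold lower number from compound 1 to compound 4 (0.07 log units; within the scatter)), and the same holds against the 3-methylphenyl of compound 3 (a 1.3-fold lower number from compound 3 to compound 4 (0.11 log units; within the scatter)). Only the 4-(trifluoromethyl)phenyl of compound 2 stands apart from the new ring (a 2.5-fold higher number from compound 2 to compound 4 (0.39 log units; beyond the scatter)). Nothing available explains these results. Still open, from the compounds shown here alone, is whether the ring nitrogen alone, in plain pyridin-3-yl, would behave the same way. Also open, going by these compounds, is what a trifluoromethyl, an amine or a carboxylic acid on the pyridine ring would do.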